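This account rests on a few compounds, and the source may have more. Where it says the series, first, only, none or still open, it means among the compounds named here.

In a functional assay on HepG2 cells (Homo sapiens) for cytotoxicity, read by MTT assay, with a stated time of 48 h (a higher number here means a weaker inhibitor, a lower number a stronger inhibitor), compound 1 `Nc1ccccc1Nc1n[n+]([O-])c2ccccc2[n+]1[O-]` gives 17400 nM and compound 2 `[O-][n+]1nc(NC2CCCCC2)[n+]([O-])c2ccccc21` gives 9500 nM. Compound 2 holds the lower of these two numbers, yet the gap to compound 1 lies within the usual scatter, so the two cannot be ranked. Compound 3 `C=CCNc1n[n+]([O-])c2ccccc2[n+]1[O-]` has not been measured; it differs from compound 2 by allyl in place of cyclohexyl on a nitrogen on an aromatic ring. Among the measured compounds shown here, no measured pair shows what such a change does, so no step beyond the scatter is expected in this assay, in either direction. For compound 3 the estimated value in this assay is 13000 nM, with a range from 4500 nM to 40000 nM, which means an expected step of a 1.4-fold higher number from compound 2 to compound 3 (0.14 log units; within the scatter).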

Compound 3, half-maximal inhibitory concentration: > 56000 nM
Compound 3: a limit, no number (the forecaster's own chance of this, stated with the estimate: 10%); middle value at least 4.3-fold (0.63 log units) away from the limit.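

Compound 3 reads as a limit of the assay, not as a number: the limit of > 56000 nM in this assay, at which 1 of the 3 values shown sits. Even so, in this assay allyl in place of cyclohexyl on a nitrogen on an aromatic ring gives an at least 5.8-fold higher number from compound 2 to compound 3 (0.77 log units; beyond the scatter). The group at this position can therefore shift the reading beyond the scatter, which compounds 1 and 2, with values within the scatter of each other, did not show.

Going by these compounds, how far the true value lies past the limit stays open. So does whether the loss of the ring or the double bond matters, which a propyl chain, a longer hexyl chain or a cyclopropyl ring on the same nitrogen could help separate.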